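A few compounds are considered here, and "the series" means these few. Any claim that something is new, unique, unknown or untested is made for them only; others in the source may bear on it.

Measured compounds:
- Compound 1, `CCN(Cc1ccccc1)C(=O)C1CCN(S(=O)(=O)c2cccc3c2OCCO3)CC1`: 53%
- Compound 2, `CCN(Cc1ccccc1)C(=O)C1CCN(S(=O)(=O)c2ccc(C)s2)CC1`: 64%

Both numbers come from a functional assay on CHO cells for positive allosteric modulation of muscarinic acetylcholine receptor M5 (Homo sapiens), read by calcium flux; on this read-out lower numbers stand for smaller maximal responses and higher numbers for larger maximal responses. Compound 1 stands at the lower of the two values, with compound 2 a number 11 percentage points higher from compound 1 to compound 2 (beyond the scatter) through swapping the group on the sulfonyl sulfur. The compound now in question, compound 3, `CCN(Cc1ccccc1)C(=O)C1CCN(S(=O)(=O)c2ccc3[nH]ncc3c2)CC1`, has not yet been measured in this assay. It differs from compound 1 as follows: 1H-indazol-5-yl in place of 2,3-dihydro-1,4-benzodioxin-5-yl on a sulfonyl sulfur. Among the measured compounds shown here, the only measured step at this same position, a number 11 percentage points higher from compound 1 to compound 2 (beyond the scatter), concerns a different entering group, so it shows only that a change here can move the response by a modest amount, without fixing the direction for this new group. The step is therefore expected to be small, a number 5 percentage points higher from compound 1 to compound 3 (within the scatter), with the value for compound 3 estimated at about 58%, within a range from 40% to 78%.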

Compound 3, largest response reached (reported as percent of maximum), in percent of the reference or control that the assay uses: 86%
The estimate for compound 3 lay 28 percentage points below the measured number; measured number outside the range, above it.
By their numbers in this assay, from the lowest: compound 1; then compound 2; then compound 3.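

In this assay the group on the sulfonyl sulfur can shift the response much further than the first two compounds suggested: 1H-indazol-5-yl in place of 2,3-dihydro-1,4-benzodioxin-5-yl gives a large gain (a number 33 percentage points higher from compound 1 to compound 3 (beyond the scatter)). The same group also outperforms 5-methylthiophen-2-yl (a number 22 percentage points higher from compound 2 to compound 3 (beyond the scatter)), so compound 3 stands clearly above both other compounds. Compared with the group it replaces in compound 1, 1H-indazol-5-yl brings a hydrogen-bond donor, but no measurement here shows whether that donor accounts for the gain.

Going by these compounds, it remains open whether a close relative such as an indol-5-yl group or a phenyl ring bearing an amine would give a similar response. These compounds also leave open whether the gain would persist if the shared core were changed.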